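Side-chain variation in the amino ester series, tail flick

This account rests on a few compounds, and the source may have more. Where it says the series, first, only, none or still open, it means among the compounds named here.

Compound 3 `CC(C)(C)OC(=O)NCCCC[C@H](NC(=O)CN(c1ncnc2c1ncn2C1CCCCO1)C1CC1)C(=O)OCc1ccccc1` stands lowest of the three numbers measured: in a functional assay on the whole organism (Tail, strain ICR) with Mus musculus as the target, in the tail flick test, with a stated time of 30 min, at a dose of 25 umol/kg by the oral route (a higher number here means a stronger effect of the compound at the dose given, a lower number a weaker effect), compound 3 gives 18.3%. Compound 1 `O=C(CN(c1ncnc2c1ncn2C1CCCCO1)C1CC1)N[C@@H](CCC(=O)OCc1ccccc1)C(=O)OCc1ccccc1` gives 32.6% in this assay, and compound 2 `CC[C@H](C)[C@H](NC(=O)CN(c1ncnc2c1ncn2C1CCCCO1)C1CC1)C(=O)OCc1ccccc1` gives 25.6%. The steps among them read a number 7 percentage points lower from compound 1 to compound 2 (within the scatter), a number 14.3 percentage points lower from compound 1 to compound 3 (beyond the scatter) and a number 7.3 percentage points lower from compound 2 to compound 3 (within the scatter); only the gap between compound 1 and compound 3 exceeds the scatter.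

Compound 4 `CSCC[C@H](NC(=O)CN(c1ncnc2c1ncn2C1CCCCO1)C1CC1)C(=O)OCc1ccccc1` is the next member. Relative to compound 3 the change is methylsulfanyl in place of 2-((tert-butoxycarbonyl)amino)ethyl on a saturated chain carbon, three bonds along the chain from an amide-type nitrogen and a carbonyl carbon. Among the compounds with values here, no measured step covers this exact exchange. The step that bears on it is a number 7.3 percentage points lower from compound 2 to compound 3 (within the scatter), in which the 4-((tert-butoxycarbonyl)amino)butyl chain entered in place of sec-butyl; compound 4 moves back to a chain of two heavy atoms, 2-(methylsulfanyl)ethyl, nearer in size to the sec-butyl of compound 2. A small upward step, within the scatter, is therefore expected. Compound 4 is expected to give 24% in this assay, with a range from 12% to 38%. The estimated step is a number 5.7 percentage points higher from compound 3 to compound 4 (within the scatter), not beyond the scatter.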

Compound 4, a percentage reported as activity, at one dose (the size of the read-out at that dose, not a potency): 30%
Beside the measured number, compound 4's estimate is 6 percentage points below it; measured number inside the range.
By their numbers in this assay, from the lowest: compounds 3, 2, 4 and 1 (each within the scatter of the next, the first and the last beyond it).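

Within the data shown here, at the saturated chain carbon, three bonds along the chain from an amide-type nitrogen and a carbonyl carbon, methylsulfanyl in place of 2-((tert-butoxycarbonyl)amino)ethyl gives a number 11.7 percentage points higher from compound 3 to compound 4 (beyond the scatter) in this assay, so compound 1 is no longer the only compound separated from compound 3. The benzyloxycarbonyl group is not needed for a reading within the scatter of compound 1, as methylsulfanyl in its place gives a number 2.6 percentage points lower from compound 1 to compound 4 (within the scatter), while the comparison with the sec-butyl compound gives a number 4.4 percentage points higher from compound 2 to compound 4 (within the scatter). No available evidence explains these steps.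

The compounds shown leave open whether the reading of compound 3 follows from the tert-butoxycarbonyl group or from the length of the 4-((tert-butoxycarbonyl)amino)butyl chain. A primary amine at the end of that butyl chain would separate the two, and a longer chain ending in methylsulfanyl would test the length alone.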